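The compounds below may be only part of what the source reports. "The series", "measured", "known", "first", "only" and "open" are said of these compounds alone.

In an ADME assay on Vero cells (Chlorocebus sabaeus) for antiproliferative activity, read by MTT assay, with a stated time of 72 h (a higher number here means a weaker inhibitor, a lower number a stronger inhibitor), compound 1 `Cc1ccc(N(C)S(=O)(=O)C2CC3OC2C(c2ccc(NC(=O)CCCCCCC(=O)O)cc2)=C3c2ccc(O)cc2)cc1` gives > 100000 nM as a limit of the assay, not a number. Compound 2 `CCN(c1ccc(C)cc1)S(=O)(=O)C1CC2OC1C(c1ccc(NC(=O)CCCCCCC(=O)O)cc1)=C2c1ccc(O)cc1` gives > 100000 nM as a limit too. Compound 3 `CCN(c1cccc(C)c1)S(=O)(=O)C1CC2OC1C(c1ccc(NC(=O)CCCCCCC(=O)O)cc1)=C2c1ccc(O)cc1` gives > 100000 nM as a limit also, so its standing is known only as a limit. For the measured compounds named here, the series so far rests on the limit of > 100000 nM in this assay, at which 3 of the 3 values shown sit, and offers no number to work from.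

The next analogue is compound 4 `CCN(c1ccc(OC)cc1)S(=O)(=O)C1CC2OC1C(c1ccc(NC(=O)CCCCCCC(=O)O)cc1)=C2c1ccc(O)cc1`, with 4-methoxyphenyl in place of 3-methylphenyl on a sulfonamide nitrogen. The closest measured precedent is the exchange of one aryl group for another on that nitrogen (a step that the two limits leave unreadable from compound 2 to compound 3). The two remaining steps also touch the groups on that nitrogen (a step that the two limits leave unreadable from compound 1 to compound 2) and (a step that the two limits leave unreadable from compound 1 to compound 3). None of the three has a readable size, so they supply neither a magnitude nor a direction.

In this assay no step beyond the usual scatter is therefore expected, and the assay will most likely again report only a limit. The estimated step is small (a number no higher from compound 3 to compound 4 (the limit leaves the size open)). The expected value for compound 4 is 100000 nM with an estimated range from 50000 nM to 200000 nM as its bounds.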

Compound 4, half-maximal inhibitory concentration: > 100000 nM
Compound 4 gave a limit, no number (the forecaster's own chance of this, stated with the estimate: 90%); the middle value sits exactly at the limit.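

The steps from compound 1, compound 2 and compound 3 to compound 4 cannot be read in this assay, and the series still offers only one limit of the assay, not a number: the limit of > 100000 nM in this assay, at which 4 of the 4 values shown sit.

The compounds shown leave open what number any of them would give in this assay, and so the size and direction of every step among them.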